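Swapping the aryl amide of compound 3 for an amine-bearing chain

A few compounds are considered here, and "the series" means these few. Any claim that something is new, unique, unknown or untested is made for them only; others in the source may bear on it.

Three pyrazoline amides have been tested in a functional assay on PC-3 cells (Homo sapiens) for cytotoxicity, read by MTT assay, with a stated time of 48 h; on this read-out higher numbers stand for weaker inhibition and lower numbers for stronger inhibition. Compound 1 `CCC(=O)N1N=C(C)CC1c1cc(Br)ccc1O` gives 37800 nM, compound 2 `CCN(CC)CC(=O)N1N=C(C)CC1c1ccccc1OC(C)=O` gives 51200 nM, and compound 3 `Cc1ccc(C(=O)N2N=C(c3cc4ccccc4oc3=O)CC2c2ccccc2)cc1` gives 13200 nM, the lowest of the three numbers and therefore the strongest inhibition observed so far, with the nearest number, that of compound 1, and the furthest, that of compound 2, both beyond the scatter. Compound 4 `CCN(CC)C1CCN(CC(=O)N2N=C(c3cc4ccccc4oc3=O)CC2c2ccccc2)CC1` keeps the core of compound 3 and changes one spot: (4-(diethylamino)piperidin-1-yl)methyl in place of 4-methylphenyl on a carbonyl carbon. Within the data shown here, no measured pair shows this kind of exchange, so its effect is unknown. For compound 4 a small step is expected, a 1.1-fold higher number from compound 3 to compound 4 (0.06 log units; within the scatter), within or just beyond the scatter, giving an estimated value of 15000 nM in this assay, with a range from 5000 nM to 45000 nM.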

Compound 4, half-maximal inhibitory concentration: 26100 nM
The estimate for compound 4 lay 1.7-fold (0.24 log units) below the measured number; low and high end bracket the measured number.
By their numbers in this assay, from the lowest: compounds 3, 4, 1 and 2 (each within the scatter of the next, the first and the last beyond it).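

Among these compounds, for the first time, a step at this carbonyl carbon can be read: in this assay, (4-(diethylamino)piperidin-1-yl)methyl in place of 4-methylphenyl gives a 2.0-fold higher number from compound 3 to compound 4 (0.30 log units; within the scatter). An aromatic carbon ring can thus give way to a non-aromatic ring carrying two nitrogens without the assay clearly separating the two compounds. Nothing available explains this result. Still open, as far as these compounds go, is how a morpholin-4-ylmethyl group, a shorter dimethylaminomethyl chain or a carboxylic acid would read at this position. Also open, from the compounds shown here alone, is whether the same exchange gives a similar step on another core.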